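This account rests on a few compounds, and the source may have more. Where it says the series, first, only, none or still open, it means among the compounds named here.

The series is a set of aryl-oxadiazole acids measured in an assay on CHO cells for displacement of a labelled ligand from sphingosine 1-phosphate receptor 4 (Homo sapiens); on this read-out higher numbers stand for weaker inhibition and lower numbers for stronger inhibition. Compound 1 `Cc1cc(CCC(=O)O)ccc1-c1noc(-c2ccc(OC(C)C)c(C#N)c2)n1` is the propanoic acid member; in this assay compound 1 returns only a limit, > 10000 nM. Compound 3 `Cc1cc([C@@H]2C[C@H]2C(=O)O)ccc1-c1noc(-c2ccc(OC(C)C)c(C#N)c2)n1` is the cyclopropane acid with a nitrile; compound 3 also reports only the assay limit in each of its entries, > 10000 nM; > 10000 nM; > 10000 nM (3 entries). Compound 2 `Cc1cc([C@@H]2C[C@H]2C(=O)O)ccc1-c1noc(-c2ccc(OC(C)C)c(C(F)(F)F)c2)n1` carries the same cyclopropane acid with a trifluoromethyl group; in this assay compound 2 likewise yields only a limit, > 10000 nM. On the numbers shown, compound 2 therefore stands at the limit of > 10000 nM in this assay, at which 2 of the 3 values shown sit, with no single value separating it from its neighbours.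

The step to compound 4 `Cc1cc(CC(C)C(=O)O)ccc1-c1noc(-c2ccc(OC(C)C)c(C(F)(F)F)c2)n1` is 2-carboxypropyl in place of 2-carboxycyclopropyl on an aromatic carbon, meta to a methyl group and para to a large group. Among the compounds with values here, no measured pair in this set spans a comparable change, so there is nothing on which to build a direction; the expectation is that the change leaves the result in this assay where compound 2 sits, at the limit rather than at a number, with no step beyond the scatter. Compound 4 is accordingly estimated at 15000 nM, within 5000 nM to 50000 nM, corresponding to an expected step that the limit leaves unreadable from compound 2 to compound 4.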

Compound 4, half-maximal inhibitory concentration: > 10000 nM
Compound 4 ended at the assay's limit; the forecaster's own chance of this, stated with the estimate: 85%; the middle value lies beyond the limit too.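

In this assay, compound 2 and compound 4 both report only a limit, so the step between them, 2-carboxypropyl in place of 2-carboxycyclopropyl, cannot be read. With every compound shown at a limit in this assay, it remains open whether any of these changes alters inhibition at all, and in which direction.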